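Adding an Ethoxy Group to Compound 2

This account rests on a few compounds, and the source may have more. Where it says the series, first, only, none or still open, it means among the compounds named here.

In a functional assay on the whole organism (strain Sprague-Dawley) for inhibition, with Rattus norvegicus as the target, with a stated time of 10 min (on this read-out higher numbers stand for an effect only at larger amounts of compound and lower numbers for an effect already at smaller amounts), compound 1 (`CCOc1ccccc1-c1ncc(C(=O)O)c(=O)[nH]1`) gives 0.5 mg/kg. Compound 2 (`Cn1c(-c2ccccc2)ncc(C(=O)O)c1=O`) gives 50 mg/kg, the higher of the two numbers and well beyond the scatter, so its effect needs the larger dose. Compound 3 (`CCOc1ccccc1-c1ncc(C(=O)O)c(=O)n1C`) has ethoxy in place of hydrogen on an aromatic carbon of compound 2: ethoxy in place of hydrogen on an aromatic carbon. Compound 1, at 0.5 mg/kg, also carries ethoxy but differs from compound 3 in a second place, so only part of that gap is expected to close. The expected change is a fall beyond the scatter, an 8.3-fold lower number from compound 2 to compound 3 (0.92 log units; beyond the scatter). Compound 3 is expected at 6 mg/kg, with an estimated range of 1 mg/kg to 35 mg/kg.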

Compound 3, dose for 50% inhibition: > 50 mg/kg
Compound 3: no number, only a limit (the forecaster's own chance of this, stated with the estimate: 10%); middle value at least 8.3-fold (0.92 log units) from the limit.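

Compound 3 gives no number, only a limit of the read-out: the limit of > 50 mg/kg in this assay, at which 1 of the 3 values shown sits. With the methyl on the aromatic nitrogen, ethoxy in place of hydrogen gives a number no lower from compound 2 to compound 3 (the limit leaves the size open) in this assay. With ethoxy present in both compounds, methyl in place of hydrogen on an aromatic nitrogen gives an at least 100-fold higher number from compound 1 to compound 3 (2.00 log units; beyond the scatter), so this single change matters greatly here. Still open, from the compounds shown here alone, is how an amine or a methoxy group in place of ethoxy would read when that nitrogen keeps its hydrogen.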